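The source may report more compounds than this note shows. Statements on the series, on what has been measured and on what is new or still open speak of the compounds shown alone.

Measured so far in a functional assay on HCC827 cells (Homo sapiens) for antiproliferative activity, read by MTT assay, with a stated time of 72 h; a lower number here means a stronger inhibitor, a higher number a weaker inhibitor:
- compound 1 `COc1ccc(Nc2cc(NC(=O)c3ccccc3)ncn2)cc1`: 5350 nM
- compound 2 `COc1ccc(OC)c(Nc2cc(Nc3ccc(F)cc3)ncn2)c1`: 1720 nM

Compound 2, at 1720 nM, holds the lower of the two numbers, and so is the stronger inhibitor of the pair. Compound 1 stands at 5350 nM, and the gap between the two lies beyond the scatter. With only these two values, no trend can be drawn for the series, and they say nothing about any single structural change.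

The next compound to be tested is compound 3 `COc1cccc(Nc2cc(Nc3cc(OC)ccc3OC)ncn2)c1`, which is compound 2 with one change: 3-methoxyphenyl in place of 4-fluorophenyl on a nitrogen on an aromatic ring. It carries 3-methoxyphenyl in place of 4-fluorophenyl on a nitrogen on an aromatic ring, and the rest of the structure stays the same. Among the compounds with values here, no measured pair shows this change, so the expectation is anchored only on compound 2 at 1720 nM. No step beyond the scatter is expected in this assay, with a slight lean towards a higher number. The estimated step of a 1.3-fold higher number from compound 2 to compound 3 (0.13 log units; within the scatter) is therefore small. The expected value for compound 3 is 2300 nM, with an estimated range of 750 nM to 7000 nM.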

Compound 3, half-maximal inhibitory concentration: 1140 nM
For compound 3 the middle estimate is 2.0-fold (0.30 log units) above the measured one; the measured number falls inside the stated range.
By their numbers in this assay, from the lowest: compounds 3 and 2 (each within the scatter of the next); then compound 1.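

In this assay, within the data shown here, the first single-place step is 3-methoxyphenyl in place of 4-fluorophenyl on a nitrogen on an aromatic ring (a 1.5-fold lower number from compound 2 to compound 3 (0.18 log units; within the scatter)), and it lies within the scatter. This position therefore takes 3-methoxyphenyl, with 8 heavy atoms and 1 hydrogen-bond acceptor, as well as 4-fluorophenyl, with 7 heavy atoms and 0 hydrogen-bond acceptors, without a step that can be told apart from repeat variation in this read-out. No supporting measurement bears on this result, so it stands as a plain observation from a single pair.

Among these compounds, the series still holds only one step at this position, and both groups in it are substituted phenyl rings, so it remains open whether the same flat picture would hold for a phenyl ring carrying an amine or a carboxylic acid, or for a longer chain on this nitrogen. Compound 1 differs from compound 2 and compound 3 in more than one place, so the contribution of its benzamide-type carbonyl link and of the other aryl group on the shared core remains unresolved.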